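Swapping trifluoromethyl for methyl on compound 3

This account rests on a few compounds, and the source may have more. Where it says the series, first, only, none or still open, it means among the compounds named here.

Compound 1 `NC(=O)c1c(NC(=O)c2ccccc2Cl)sc2c1CCN(C(=O)Nc1ccccc1Cl)C2`: 45400 nM
Compound 2 `NC(=O)c1c(NC(=O)c2ccccc2F)sc2c1CCN(C(=O)Nc1ccccc1Cl)C2`: a limit, > 50000 nM
Compound 3 `NC(=O)c1c(NC(=O)c2ccc(C(F)(F)F)cc2)sc2c1CCN(C(=O)Nc1ccccc1Cl)C2`: a limit, > 50000 nM

All three were tested in a functional assay on HeLa cells (Homo sapiens) for antiproliferative activity, with a stated time of 24 h; on this read-out higher numbers stand for weaker inhibition and lower numbers for stronger inhibition. Among the measured compounds shown here, compound 1 is the only one with an actual number. For compound 2 the result is a limit of the assay, not a number. For compound 3 the result is likewise a limit of the assay. Compound 3 therefore sits at the weak end of what was seen, at the limit of > 50000 nM in this assay, at which 2 of the 3 values shown sit.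

Compound 4 `Cc1ccc(C(=O)Nc2sc3c(c2C(N)=O)CCN(C(=O)Nc2ccccc2Cl)C3)cc1` differs from compound 3 by methyl in place of trifluoromethyl on an aromatic carbon. For the measured compounds named here, the steps that bear on this are an at least 1.1-fold higher number from compound 1 to compound 3 (0.04 log units; that floor lies within the scatter) and a step that the two limits leave unreadable from compound 2 to compound 3. Neither gives a readable size, so no step beyond the scatter is expected. Compound 4 is expected to stay near the limit, a step of a number no higher from compound 3 to compound 4 (the limit leaves the size open). The estimate for compound 4 is 50000 nM, between 20000 nM and 120000 nM.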

Compound 4, half-maximal inhibitory concentration: 32900 nM
The estimate for compound 4 lay 1.5-fold (0.18 log units) above the measured number, and the stated range covers the measured number.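

Methyl at this position gives a measured number, not the limit seen with trifluoromethyl: the limit of > 50000 nM in this assay, at which 2 of the 4 values shown sit. The steps read an at least 1.5-fold lower number from compound 3 to compound 4 (0.18 log units; that floor lies within the scatter) and an at least 1.5-fold lower number from compound 2 to compound 4 (0.18 log units; that floor lies within the scatter); these are floors only, and the true differences could be larger. Against the one other measured number, the step reads a 1.4-fold lower number from compound 1 to compound 4 (0.14 log units; within the scatter), so 4-methylphenyl and 2-chlorophenyl cannot be told apart here.

Going by these compounds, compound 3 carries only a limit, and the true size of its step stays open. On these data alone, whether an amine or a carboxylic acid on this aromatic carbon would give a lower number than methyl also stays open.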